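Bromopyridinyl Piperazine Sulfonamide: Predicted CXCR3 Antagonist Potency

A few compounds are considered here, and "the series" means these few. Any claim that something is new, unique, unknown or untested is made for them only; others in the source may bear on it.

Compound 1, `CC1(C)[C@@H]2CC[C@@]1(CS(=O)(=O)N1CCN(c3ncccc3C(F)(F)F)CC1)C(=O)C2`: > 31600 nM
Compound 2, `CC1(C)[C@@H]2CC[C@@]1(CS(=O)(=O)N1CCN(c3cc(C(F)(F)F)ccn3)CC1)C(=O)C2`: 25100 nM

Of the compounds shown here, two have been measured in a functional assay on CHO-K1 cells for antagonist activity at C-X-C chemokine receptor type 3 (Homo sapiens), read by FLIPR and calcium flux; a lower number here means a stronger inhibitor, a higher number a weaker inhibitor. Compound 1 gives only the limit > 31600 nM, not a number; this is the limit of > 31600 nM in this assay, at which 1 of the 2 values shown sits. Among the compounds with values here, compound 2, `CC1(C)[C@@H]2CC[C@@]1(CS(=O)(=O)N1CCN(c3cc(C(F)(F)F)ccn3)CC1)C(=O)C2`, gives 25100 nM in this assay, the only actual number in the set. Within the data shown here, the single step, an at least 1.2-fold lower number from compound 1 to compound 2 (0.10 log units; that floor lies within the scatter), moves the trifluoromethyl around the pyridin-2-yl ring and yields a change whose floor lies within the scatter.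

Compound 3, `CC1(C)[C@@H]2CC[C@@]1(CS(=O)(=O)N1CCN(c3ccc(Br)cn3)CC1)C(=O)C2`, is the next compound. It differs from compound 2 by 5-bromopyridin-2-yl in place of 4-(trifluoromethyl)pyridin-2-yl on an amine nitrogen in a ring. Among the measured compounds shown here, no measured step swaps the substituent itself, so the only relevant evidence is the step from compound 1 to compound 2, which was small. Compound 3 is therefore expected to remain a weak inhibitor in this assay, with a step of a 1.1-fold lower number from compound 2 to compound 3 (0.06 log units; within the scatter) that is not expected to exceed the scatter.

Compound 3 is estimated at 22000 nM, between 6000 nM and 70000 nM, with a real chance that only a limit is reported.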

Compound 3, half-maximal inhibitory concentration: 1580 nM
The estimate for compound 3 lay 14-fold (1.14 log units) above the measured number, outside the stated range (below it).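

In this assay, within the data shown here, the group on the amine nitrogen in a ring proves able to shift the number well beyond the scatter, which the earlier compounds did not show. Taking 5-bromopyridin-2-yl in place of 4-(trifluoromethyl)pyridin-2-yl gives a 16-fold lower number from compound 2 to compound 3 (1.20 log units; beyond the scatter), whereas the one earlier step, between the two trifluoromethyl pyridines, had a floor within the scatter. Taking the same bromopyridine in place of 3-(trifluoromethyl)pyridin-2-yl gives an at least 20-fold lower number from compound 1 to compound 3 (1.30 log units; beyond the scatter), so the bromopyridine stands clearly apart from both trifluoromethyl pyridines, though this second step rests on compound 1, which is held only as a limit and not a number: the limit of > 31600 nM in this assay, at which 1 of the 3 values shown sits.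

The change replaces the substituent and also alters where it sits on the pyridine, and these values cannot tell whether the bromine or its placement carries the step. Also open, going by these compounds, is whether a chlorine, a nitrile or a methoxy group on the pyridine, or a phenyl ring in place of the pyridine, would keep the number of compound 3 on the same shared core.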